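This account rests on a few compounds, and the source may have more. Where it says the series, first, only, none or still open, it means among the compounds named here.

Compound 1 `O=C(Nc1ccc(NCc2cc(F)cc(Cl)c2)cc1Cl)c1cc(Cl)ccc1O` gives 11100 nM
Compound 2 `O=C(Nc1ccc(NCc2ccc(O)nc2)cc1Cl)c1cc(Cl)ccc1O` gives 98500 nM

In an ADME assay on A549 cells (Homo sapiens) for cytotoxicity, read by resazurin assay, with a stated time of 48 h (a higher number here means that more compound is tolerated, a lower number that less compound is tolerated), compound 2 holds the higher of the two numbers at 98500 nM and is the reference here. Compound 3 `CC(C)(C)OC(=O)NCCNc1ccc(NC(=O)c2cc(Cl)ccc2O)c(Cl)c1` differs from it as follows: ((tert-butoxycarbonyl)amino)methyl in place of 6-hydroxypyridin-3-yl on a saturated chain carbon bound to a nitrogen on an aromatic ring. Among the compounds with values here, one measured step bears on this place, an 8.9-fold higher number from compound 1 to compound 2 (0.95 log units; beyond the scatter), and it shows that the group here can move the number beyond the scatter. It gives a size but no direction for a group without a ring. A modest move to a lower number is expected, with a 3.3-fold lower number from compound 2 to compound 3 (0.52 log units; beyond the scatter) as the estimated step. Compound 3 is estimated at 30000 nM with 10000 nM to 90000 nM as the expected range.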

Compound 3, half-maximal cytotoxic concentration: 25000 nM
Beside the measured number, compound 3's estimate is 1.2-fold (0.08 log units) above it; the range from low to high includes it.
By their numbers in this assay, from the lowest: compound 1; then compound 3; then compound 2.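

In this assay, a group with no ring, on a saturated chain carbon bound to a nitrogen on an aromatic ring, falls between the two ring-bearing groups, with a 3.9-fold lower number from compound 2 to compound 3 (0.60 log units; beyond the scatter) and a 2.3-fold higher number from compound 1 to compound 3 (0.35 log units; beyond the scatter). Having a ring or not therefore does not by itself set the order of compound 1, compound 3 and compound 2. Nothing available explains either step.

Still open, on these data alone, is whether the number follows the tert-butoxycarbonyl group or the chain carrying it. A free primary amine, a carboxylic acid or a longer chain at this place would separate the two.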